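The source may hold more compounds than are shown below. What is called first, only, known or untested is meant among the compounds shown, and "the series" means these compounds.

Compound 1 `N#Cc1cnc(NCc2cnccc2C(F)(F)F)cc1NC[C@H]1C[C@H](O)C1`: 700 nM
Compound 2 `CO[C@H]1CC[C@H](CNc2cc(NCc3cnccc3C(F)(F)F)ncc2C#N)CC1`: 330 nM
Compound 3 `N#Cc1cnc(NCc2cnccc2C(F)(F)F)cc1NCCC1CCOCC1`: 1200 nM

In an assay on isolated protein for inhibition of protein kinase C theta type (Homo sapiens), read by TR-FRET, with a stated time of 2 h (on this read-out higher numbers stand for weaker inhibition and lower numbers for stronger inhibition), compound 3 gives the highest number of the three, meaning the weakest inhibition so far. Compound 4 `CC1(C)C[C@H](Nc2cc(NCc3cnccc3C(F)(F)F)ncc2C#N)CC[C@@H]1O` differs from it by 4-hydroxy-3,3-dimethylcyclohexyl in place of 2-(oxan-4-yl)ethyl on a nitrogen on an aromatic ring. Among the compounds with values here, two measured steps bear on this change. From compound 1 to compound 3 the change was a 1.7-fold higher number from compound 1 to compound 3 (0.23 log units; within the scatter), and from compound 2 to compound 3 it was a 3.6-fold higher number from compound 2 to compound 3 (0.56 log units; beyond the scatter); in both, the ring carried on a longer chain gave the weaker result, and the hydroxyl-bearing ring of compound 1 sat close to the measured middle. Moving to a ring bound directly to the nitrogen, with a hydroxyl group, is therefore expected to give a modest step toward stronger inhibition, a 2.7-fold lower number from compound 3 to compound 4 (0.43 log units; beyond the scatter). Compound 4 is estimated at 450 nM, with a range from 150 nM to 1300 nM.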

Compound 4, half-maximal inhibitory concentration: 7 nM
Compound 4: middle estimate off by 64-fold (1.81 log units), on the high side; measured number outside the range, below it.
By their numbers in this assay, from the lowest: compound 4; then compound 2; then compounds 1 and 3 (each within the scatter of the next).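

In this assay, the groups on this nitrogen in the three earlier compounds differed only modestly, yet 4-hydroxy-3,3-dimethylcyclohexyl brings far stronger inhibition (a 170-fold lower number from compound 3 to compound 4 (2.23 log units; beyond the scatter); a 47-fold lower number from compound 2 to compound 4 (1.67 log units; beyond the scatter); a 100-fold lower number from compound 1 to compound 4 (2.00 log units; beyond the scatter)). Compound 1 also carries a hydroxyl group, so a hydroxyl group alone does not produce this gain. No measurement here explains the gain.

The compounds shown leave open how much comes from the two methyl groups, the hydroxyl group or the ring bound directly to the nitrogen. Plain 4-hydroxycyclohexyl, or an amine in place of the hydroxyl group, would help separate these.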